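The compounds below may be only part of what the source reports. "The series", "measured", "known", "first", "only" and "open" are said of these compounds alone.

Measured so far in a functional assay on DU-145 cells (Homo sapiens) for cytotoxicity, read by MTT assay, with a stated time of 48 h; a higher number here means a weaker inhibitor, a lower number a stronger inhibitor:
- compound 1 `CC(C)=CCC/C(C)=C/CC/C(C)=C/CC[C@@H]1[C@@]2(C)C/C(=C\c3ccc(OCc4cn(-c5ccccc5)nn4)cc3)C(=O)C(C)(C)[C@@H]2CC[C@@]1(C)O` gives 21000 nM
- compound 2 `CC(C)=CCC/C(C)=C/CC/C(C)=C/CC[C@@H]1[C@@]2(C)C/C(=C\c3ccc(OCc4cn(-c5ccc(Cl)cc5)nn4)cc3)C(=O)C(C)(C)[C@@H]2CC[C@@]1(C)O` gives 79400 nM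
- compound 3 `CC(C)=CCC/C(C)=C/CC/C(C)=C/CC[C@@H]1[C@@]2(C)C/C(=C\c3ccc(OCc4cn(-c5ccccc5C#N)nn4)cc3)C(=O)C(C)(C)[C@@H]2CC[C@@]1(C)O` gives 25100 nM

Compound 3 holds the second highest of the three numbers. The step of a 1.2-fold higher number from compound 1 to compound 3 (0.08 log units; within the scatter) stays within the scatter, while the step of a 3.2-fold lower number from compound 2 to compound 3 (0.50 log units; beyond the scatter) lies beyond it.

Next is compound 4 `CC(C)=CCC/C(C)=C/CC/C(C)=C/CC[C@@H]1[C@@]2(C)C/C(=C\c3ccc(OCc4cn(-c5ccc(F)c(Cl)c5)nn4)cc3)C(=O)C(C)(C)[C@@H]2CC[C@@]1(C)O`, with 3-chloro-4-fluorophenyl in place of 2-cyanophenyl on an aromatic nitrogen. Within the data shown here, two measured steps bear on this. Adding cyano gave the small step above, and adding chloro gave a 3.8-fold higher number from compound 1 to compound 2 (0.58 log units; beyond the scatter). Among the measured compounds shown here, no measured compound carries fluoro. A modest rise in this assay is therefore expected, with an estimated 1.5-fold higher number from compound 3 to compound 4 (0.18 log units; within the scatter). Compound 4 is estimated at 38000 nM, with an expected range of 15000 nM to 95000 nM.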

Compound 4, half-maximal inhibitory concentration: 28400 nM
For compound 4 the middle estimate is 1.3-fold (0.13 log units) above the measured one, within the range that was stated.
By their numbers in this assay, from the lowest: compounds 1, 3 and 4 (each within the scatter of the next); then compound 2.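

In this assay, replacing 2-cyanophenyl with 3-chloro-4-fluorophenyl on the aromatic nitrogen gives a 1.1-fold higher number from compound 3 to compound 4 (0.05 log units; within the scatter), and replacing phenyl gives a 1.4-fold higher number from compound 1 to compound 4 (0.13 log units; within the scatter), so this position tolerates a doubly halogenated ring without leaving the scatter. Replacing 4-chlorophenyl gives a 2.8-fold lower number from compound 2 to compound 4 (0.45 log units; beyond the scatter), so a chloro group on this ring does not by itself bring the higher number seen for compound 2. No available evidence explains this difference between the two chloro compounds. Still open, from the compounds shown here alone, is whether an amine or a carboxylic acid on this ring would move the number beyond the scatter from compound 1.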